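Enlarging the Sulfonyl Aryl Group of Compound 1

The source may report more compounds than this note shows. Statements on the series, on what has been measured and on what is new or still open speak of the compounds shown alone.

Measured so far in an assay on MDA-MB-231 cells for binding affinity to C-X-C chemokine receptor type 4 (Homo sapiens), read by microscopy, with stated times of 10 min and 30 min; a higher number here means that more compound is needed for the effect, a lower number that less compound is needed:
Compound 1 `O=C(NCc1ccc(CNS(=O)(=O)c2ccc(Cl)cc2)cc1)c1ccc(CNc2ncccn2)cc1` gives 100 nM.
Compound 2 `O=C(NCc1ccc(CNS(=O)(=O)c2cccc3ccccc23)cc1)c1ccc(CNc2ncccn2)cc1` gives 1000 nM.
Compound 3 `O=C(NCc1ccc(CNS(=O)(=O)c2cccc(Cl)c2)cc1)c1ccc(CNc2ncccn2)cc1` gives 1 nM.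

Compound 1 stands second highest of the three: compound 2 sits above it (a 10-fold higher number from compound 1 to compound 2 (1.00 log units; beyond the scatter)), while compound 3 sits far below it (a 100-fold lower number from compound 1 to compound 3 (2.00 log units; beyond the scatter)). Compound 4 `O=C(NCc1ccc(CNS(=O)(=O)c2ccc(-c3ccc(F)cc3)cc2)cc1)c1ccc(CNc2ncccn2)cc1` differs from compound 1 in one place: 4-fluorophenyl in place of chloro on an aromatic carbon. The step that bears on this is the one where naphthalen-1-yl replaced 4-chlorophenyl on the sulfonyl sulfur, giving a 10-fold higher number from compound 1 to compound 2 (1.00 log units; beyond the scatter). Since compound 4 likewise carries more ring on that sulfonyl arm, a modest rise in this assay is expected, namely a 4.0-fold higher number from compound 1 to compound 4 (0.60 log units; beyond the scatter). Compound 4 is therefore estimated at 400 nM, within a range of 80 nM to 2000 nM.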

Compound 4, effective concentration (reported as EC, without a stated level of effect): 1000 nM
The estimate for compound 4 lay 2.5-fold (0.40 log units) below the measured number; the range from low to high includes it.
By their numbers in this assay, from the lowest: compound 3; then compound 1; then compounds 2 and 4 (each within the scatter of the next).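

In this assay, placing 4-fluorophenyl in place of chloro on this aromatic carbon gives a 10-fold higher number from compound 1 to compound 4 (1.00 log units; beyond the scatter), a modest rise. The earlier compounds shown here moved the chloro or replaced the whole ring on the sulfonyl sulfur, whereas this change keeps that ring and shows that adding a second one at this carbon raises the number. Nothing available explains the rise.

From the compounds shown here alone, what a small group such as methyl, or an amine, would do at this carbon remains open. So does whether 4-fluorophenyl would cause a similar rise on the carbon that carries chloro in compound 3.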